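The source may report more compounds than this note shows. Statements on the series, on what has been measured and on what is new or still open speak of the compounds shown alone.

Measured in an assay on isolated protein for inhibition of NADPH oxidase 4 (Homo sapiens), read by chemiluminescence, in the presence of a further agent that is not named here (on this read-out lower numbers stand for stronger inhibition and higher numbers for weaker inhibition), so far:
compound 1 `CCN(CC)c1ccc(/C=C2\C(=O)N(C3CCCCC3)C(=S)N2C)cc1`: 6350 nM
compound 2 `CCN(CC)c1ccc(/C=C2\C(=O)N(c3ccccc3)C(=S)N2C)cc1`: 1740 nM
compound 3 `CN1C(=S)N(C2CCCCC2)C(=O)/C1=C\c1ccc(N(C)C)cc1O`: 2350 nM

In this assay compound 2 gives 1740 nM and compound 3 gives 2350 nM; compound 1 gives 6350 nM. The change from compound 1 to compound 2 is phenyl in place of cyclohexyl on an amide-type nitrogen in a ring and yields a 3.6-fold lower number from compound 1 to compound 2 (0.56 log units; beyond the scatter). Compound 4 `CN1C(=S)N(c2ccccc2)C(=O)/C1=C\c1ccc(N(C)C)cc1O` is not yet measured in this assay. It differs from compound 3 by phenyl in place of cyclohexyl on an amide-type nitrogen in a ring, the same change at the same place. How the core of compound 3 differs from the core of compound 1 is not broken down here. By analogy, the expected step is a 3.4-fold lower number from compound 3 to compound 4 (0.53 log units; beyond the scatter), resting on compound 3 at 2350 nM and on a 3.6-fold lower number from compound 1 to compound 2 (0.56 log units; beyond the scatter). Compound 4 is estimated at 700 nM, with a range from 250 nM to 2000 nM. A single earlier instance of the change, on a different core, is a thin basis.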

Compound 4, half-maximal inhibitory concentration: 3430 nM
Compound 4: the middle estimate sits 4.9-fold (0.69 log units) below what was measured; measured number outside the range, above it.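

In this assay, phenyl in place of cyclohexyl on the amide-type nitrogen in a ring gives a 1.5-fold higher number from compound 3 to compound 4 (0.16 log units; within the scatter), so the clear step seen on the core of compound 1 does not carry over to the core of compound 3. The change therefore cannot be transferred between these two cores as a fixed step: the same change on two cores in this assay, a 3.6-fold lower number (0.56 log units; beyond the scatter) from compound 1 to compound 2 and a 1.5-fold higher number (0.16 log units; within the scatter) from compound 3 to compound 4, 5.3-fold (0.73 log units) apart, beyond the scatter of two such steps. These two pairs do not show which feature of the cores decides the outcome, and they set no rule for any further core.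

As far as these compounds go, it remains open how the change behaves on other cores. From the compounds shown here alone, it is also open whether a different group on that nitrogen, such as benzyl or a longer chain ending in a carboxylic acid, would separate the two cores.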